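A few compounds are considered here, and "the series" means these few. Any claim that something is new, unique, unknown or untested is made for them only; others in the source may bear on it.

Measured compounds:
compound 1 `O=C(/C=C\Nc1ccc(C(F)(F)F)cc1)c1cn(-c2ccccc2)nc1-c1ccc(Cl)cc1` — > 50000 nM
compound 2 `COc1ccc(-c2nn(-c3ccccc3)cc2C(=O)/C=C\Nc2ccc(F)cc2)cc1` — 8910 nM
compound 3 `COc1ccc(-c2nn(-c3ccccc3)cc2C(=O)/C=C\Nc2ccc(Cl)cc2)cc1` — 8860 nM

In a functional assay on U-87MG ATCC cells (Homo sapiens) for antiproliferative activity, read by MTT assay, with a stated time of 48 h (on this read-out lower numbers stand for stronger inhibition and higher numbers for weaker inhibition), compound 1 gives only a limit, > 50000 nM, which is a limit of the assay and not a number. Compound 2 gives 8910 nM in this assay, and compound 3 gives 8860 nM. Compound 3 has the lowest of the two numbers shown, but the step from compound 2 to compound 3 is a 1.0-fold lower number from compound 2 to compound 3 (0.00 log units; within the scatter), so the two compounds cannot be set in order.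

Compound 4 `COc1ccc(-c2nn(-c3ccccc3)cc2C(=O)/C=C\Nc2ccc(C(F)(F)F)cc2)cc1` has not yet been measured. It differs from compound 3 in one place: trifluoromethyl in place of chloro on an aromatic carbon. For the measured compounds named here, the only measured step that touches the same position, the step from compound 2 to compound 3, gave a 1.0-fold lower number from compound 2 to compound 3 (0.00 log units; within the scatter). Going by the values given here, compound 1, which also carries a trifluoromethyl on the anilino ring but differs from compound 4 elsewhere, sits at the limit described by the limit of > 50000 nM in this assay, at which 1 of the 3 values shown sits; no single step joins it to compound 4, so its value shows only that a trifluoromethyl anilino compound of this series can fall outside the measurable range.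

Compound 4 is therefore expected to be weaker than compound 3 in this assay by about a 1.8-fold higher number from compound 3 to compound 4 (0.26 log units; within the scatter), with a real chance of a limit. The estimate for compound 4 is 16000 nM, with a range from 5000 nM to 50000 nM.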

Compound 4, half-maximal inhibitory concentration: > 50000 nM
Compound 4 was reported as a limit; the forecaster's own chance of this, stated with the estimate: 30%; middle value at least 3.1-fold (0.49 log units) away from the limit.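

At this position, on an aromatic carbon para to a large group, the earlier pair had left fluoro and chloro without any readable order, and only now does a change here produce a step beyond the scatter. In this assay trifluoromethyl in place of chloro gives an at least 5.6-fold higher number from compound 3 to compound 4 (0.75 log units; beyond the scatter), and trifluoromethyl in place of fluoro gives an at least 5.6-fold higher number from compound 2 to compound 4 (0.74 log units; beyond the scatter), so trifluoromethyl stands apart from both halogens at this position, although neither step has a fixed size. The value of compound 4 is a limit of the assay and not a number: the limit of > 50000 nM in this assay, at which 2 of the 4 values shown sit.

The step between compound 1 and compound 4, methoxy in place of chloro on the other aromatic ring, cannot be read, so the compounds shown do not tell whether that group has any bearing on the trifluoromethyl compounds. They also leave open how a nitrile, an amine or a plain hydrogen at this position would stand against the fluoro and chloro compounds, and whether any group here would give a lower number than those two.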